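A few compounds are considered here, and "the series" means these few. Any claim that something is new, unique, unknown or untested is made for them only; others in the source may bear on it.

Measured in a functional assay on L02 cells (Homo sapiens) for inhibition, read by Griess assay, with stated times of 1 h and 24 h; on this read-out higher numbers stand for weaker inhibition and lower numbers for stronger inhibition:
Compound 1 `CN1CCN(c2nc(/C=C/c3ccccc3)nc3ccsc23)CC1`: 198000 nM
Compound 2 `CNc1nc(/C=C/c2cc(OC)c(OC)c(OC)c2)nc2ccsc12`: > 1000000 nM

Compound 2 gives > 1000000 nM in this assay, which is a limit of the assay and not a number. Its true position is therefore unknown, and it can only be said to lie at the weak end of the values seen so far.

Compound 3 `COc1cc(/C=C/c2nc(N3CCN(C)CC3)c3sccc3n2)cc(OC)c1OC` has not yet been measured. It carries 4-methylpiperazin-1-yl in place of methylamino on an aromatic carbon, next to the ring nitrogen (4-methylpiperazin-1-yl in place of methylamino on an aromatic carbon). Among the measured compounds shown here, no measured pair isolates this change. Compound 1 also bears 4-methylpiperazin-1-yl and gives 198000 nM, so a measurable value in the same region is expected, though the two compounds differ elsewhere. The expected change, toward stronger inhibition, is an at least 5.0-fold lower number from compound 2 to compound 3 (0.69 log units; beyond the scatter). For compound 3 the estimated value is 200000 nM, with an expected range of 40000 nM to 900000 nM.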

Compound 3, half-maximal inhibitory concentration: > 1000000 nM
Compound 3: no number, only a limit (the forecaster's own chance of this, stated with the estimate: 25%); middle value at least 5.0-fold (0.69 log units) away from the limit.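

In this assay compound 2 and compound 3 both stand at a limit and not a number, so no step can be read between them: the limit of > 1000000 nM in this assay, at which 2 of the 3 values shown sit. Going by these compounds, whether 4-methylpiperazin-1-yl in place of methylamino changes inhibition on this shared core, and in which direction, stays open.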